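Chain Extension on the Acid Arm of Compound 1

The compounds below may be only part of what the source reports. "The series", "measured", "known", "first", "only" and "open" are said of these compounds alone.

Working notes on a small platelet series. Compound 1 `O=C(O)CN1Cc2ccc(NC(=O)c3ccc4c(c3)CNCC4)cc2C1=O` is the weaker of the two measured entries: in a functional assay on a cell-free system (Platelet, plasma, Homo sapiens) for inhibition (on this read-out higher numbers stand for weaker inhibition and lower numbers for stronger inhibition), compound 1 gives 120000 nM. Compound 2 `CC(CC(=O)O)N1Cc2ccc(NC(=O)c3ccc(N4CCNCC4)cc3)cc2C1=O`, with a different amine-bearing aryl group and a longer acid arm, gives 3740 nM in this assay, a much lower number, beyond the scatter. For the measured compounds named here, no single-point step between measured compounds exists in this set, so nothing can be assigned to one change alone.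

Compound 3 `O=C(O)CCCN1Cc2ccc(NC(=O)c3ccc4c(c3)CNCC4)cc2C1=O` is not yet measured. It differs from compound 1 by 2-carboxyethyl in place of carboxy on a saturated chain carbon bound to an amide-type nitrogen in a ring. The only measured companion, compound 2, shows that a longer acid arm can sit beside a far lower number, though it also carries a different aryl amine. The expected step in this assay is therefore a lowering, an 8.0-fold lower number from compound 1 to compound 3 (0.90 log units; beyond the scatter), of moderate size, but the supporting evidence is thin. Compound 3 is estimated at 15000 nM, with a range from 3000 nM to 70000 nM.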

Compound 3, half-maximal inhibitory concentration: 330000 nM
The estimate for compound 3 lay 22-fold (1.34 log units) below the measured number; the whole stated range lies below it.
By their numbers in this assay, from the lowest: compound 2; then compound 1; then compound 3.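

For the compounds shown here, on the shared core, replacing carboxy with 2-carboxyethyl on a saturated chain carbon bound to an amide-type nitrogen in a ring gives the first single-change reading at this position. In this assay, the step is a 2.8-fold higher number from compound 1 to compound 3 (0.44 log units; beyond the scatter), so the number rises, and inhibition weakens, with this extension. Lengthening the acid arm alone therefore does not lower the number on this core, and the much lower number of compound 2 cannot be credited to arm length. Nothing in hand gives a measured reason for the rise.

Two arm lengths define no trend, so an acid arm of intermediate length could fall on either side of compound 1. On these data alone, whether a branched chain or a tetrazole in place of the carboxylic acid would lower the number on this core also remains open.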